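The source may report more compounds than this note shows. Statements on the series, on what has been measured and on what is new or still open speak of the compounds shown alone.

In a physicochemical assay for solubility, with a stated time of 24 h, tested at 30 mg/mL (on this read-out higher numbers stand for higher solubility and lower numbers for lower solubility), two compounds have been measured so far. Compound 1 `O=C(CCCCNc1c(Nc2ccccc2)c(=O)c1=O)NO` gives 32000000 nM, and compound 2 `O=C(CCCCCNc1c(NCc2ccccc2)c(=O)c1=O)NO` gives 5700000 nM. Compound 2 therefore holds the lower of the two numbers, and the gap between them lies beyond the usual scatter.

Compound 3 `COc1ccc(Nc2c(NCCCCCC(=O)NO)c(=O)c2=O)cc1` is the next to be read in this assay. It keeps the rest of compound 2 unchanged, but 4-methoxyphenyl stands in place of benzyl on a nitrogen on an aromatic ring (4-methoxyphenyl in place of benzyl on a nitrogen on an aromatic ring).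

Going by the values given here, no measured pair isolates this change. Compound 1 at 32000000 nM differs from compound 2 in more than one place, and its higher number cannot be assigned to any single difference. The expectation therefore stays anchored on compound 2 at 5700000 nM, with no step beyond the scatter expected and, if anything, a slight move downward. The estimated change is a 1.1-fold lower number from compound 2 to compound 3 (0.06 log units; within the scatter), though the uncertainty is wide in both directions. For compound 3 the expected value is 5000000 nM, with an estimated range from 1500000 nM to 20000000 nM.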

Compound 3, solubility: 300000 nM
Estimate against measurement, compound 3: 17-fold (1.22 log units) above; the measured number lies below the stated range.
By their numbers in this assay, from the lowest: compound 3; then compound 2; then compound 1.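

In this assay, 4-methoxyphenyl in place of benzyl on a nitrogen on an aromatic ring gives a 19-fold lower number from compound 2 to compound 3 (1.28 log units; beyond the scatter). Going by these compounds alone, this is the first single-place change to be read here, and it shows that the group on this nitrogen can by itself move the number well beyond the scatter, even though the group leaving and the group entering each carry one six-membered aromatic ring of carbon only and no net charge. Nothing given here accounts for the size of this step.

The step combines two differences, the replacement of benzyl by a group attached directly through its ring and the presence of the methoxy group, and the compounds shown do not separate them; a plain phenyl or a 4-methoxybenzyl on the same chain would tell them apart. Also open, from the compounds shown here alone, is how this position responds to a group of another kind, such as a morpholine or a carboxylic acid, and whether the same change would give a similar step on the shorter chain of compound 1.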